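This account rests on a few compounds, and the source may have more. Where it says the series, first, only, none or still open, it means among the compounds named here.

Of the compounds shown here, three have so far been measured in an assay on isolated protein for inhibition of aldehyde dehydrogenase 1A1 (Homo sapiens), read by spectrophotometry, tested at 10 uM; a lower number here means less inhibition, a higher number more inhibition at the concentration tested (going by the name of the read-out). Compound 1 `CCn1c(CN2CCN(C(=O)C3CC3)CC2)nc2ccccc21` gives 20.8%. Compound 2 `Cc1cccc(Cn2c(CN3CCN(C(=O)c4ccc(C(F)(F)F)cc4)CC3)nc3ccccc32)c1` gives 22.9%. Compound 3 `Cc1cccc(Cn2c(OC3CCN(C(=O)C4CC4)CC3)nc3ccccc32)c1` gives 80.6%. Among the measured compounds shown here, of these three numbers, the one for compound 2 is the second highest. Compound 1 and compound 2 lie within the usual scatter of each other, so the two cannot be told apart on these numbers; compound 3 sits well above compound 2, by an amount beyond the scatter. For the measured compounds named here, no two of the measured compounds differ from one another in a single place, so there is no single measured step to lean on.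

Compound 4 `Cc1cccc(Cn2c(CN3CCN(C(=O)c4ccc(C#N)cc4)CC3)nc3ccccc32)c1` is the next compound to be measured in this assay. It differs from compound 2 in one place only: cyano in place of trifluoromethyl on an aromatic carbon. Going by the values given here, none of the measured compounds shows what this exchange does, so the expectation rests on the shared core of compound 2 alone. The step that is expected from compound 2 to compound 4, a number 0.9 percentage points lower from compound 2 to compound 4 (within the scatter), is small, with no clear direction and most likely no larger than the scatter. Compound 4 is therefore estimated to give 22%, in a range from 8% to 40%.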

Compound 4, a percentage reported as inhibition, at one concentration (the size of the read-out at that concentration, not a potency): 20.8%
For compound 4 the middle estimate is 1.2 percentage points above the measured one, and the stated range covers the measured number.
By their numbers in this assay, from the lowest: compounds 1, 4 and 2 (each within the scatter of the next); then compound 3.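

In this assay, putting cyano in place of trifluoromethyl on the aromatic carbon para to a large group gives a number 2.1 percentage points lower from compound 2 to compound 4 (within the scatter). Among the compounds shown here, this is the first single-place exchange measured, and it shows that these two groups cannot be told apart at this position on these numbers, although they differ in their count of heavy atoms and of hydrogen-bond acceptors. Nothing further is available to explain this result.

On these data alone, it remains open whether an amine or a carboxylic acid on the same aromatic carbon would give a number beyond the scatter from compound 2. Also open is which structural change accounts for the much higher reading of compound 3, which gives 80.6%, as no single measured step yet connects it to compound 2 or compound 4.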